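A few compounds are considered here, and "the series" means these few. Any claim that something is new, unique, unknown or untested is made for them only; others in the source may bear on it.

Compound 1 `COc1ccc(NC(=O)/C=C/C(=O)N2C/C(=C\c3ccc([N+](=O)[O-])cc3)C(=O)/C(=C/c3ccc([N+](=O)[O-])cc3)C2)cc1` gives 940 nM in a functional assay on Molt4/C8 cells (Homo sapiens) for cytotoxicity; on this read-out higher numbers stand for weaker inhibition and lower numbers for stronger inhibition; compound 2 `O=C(/C=C/C(=O)N1C/C(=C\c2ccc([N+](=O)[O-])cc2)C(=O)/C(=C/c2ccc([N+](=O)[O-])cc2)C1)Nc1ccc([N+](=O)[O-])cc1` gives 430 nM; compound 3 `Cc1cccc(C)c1NC(=O)/C=C/C(=O)N1C/C(=C\c2ccc([N+](=O)[O-])cc2)C(=O)/C(=C/c2ccc([N+](=O)[O-])cc2)C1` gives 210 nM.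

Compound 3 holds the lowest of the three numbers: its nearest neighbour is compound 2, at a 2.0-fold lower number from compound 2 to compound 3 (0.31 log units; beyond the scatter), and the furthest is compound 1, at a 4.5-fold lower number from compound 1 to compound 3 (0.65 log units; beyond the scatter). Compound 4 `O=C(/C=C/C(=O)N1C/C(=C\c2ccc([N+](=O)[O-])cc2)C(=O)/C(=C/c2ccc([N+](=O)[O-])cc2)C1)Nc1ccccc1` differs from compound 3 by phenyl in place of 2,6-dimethylphenyl on an amide-type nitrogen. The two steps that bear on this are those from compound 1 and compound 2 to compound 3, both modest and both beyond the scatter, and both lead to compound 3 as the low point. Since phenyl sits between those aryl groups and the 2,6-dimethylphenyl, compound 4 is expected to give a somewhat higher number in this assay, the step of a 1.9-fold higher number from compound 3 to compound 4 (0.28 log units; within the scatter) being expected. The estimate for compound 4 is 400 nM, with a range from 150 nM to 1000 nM.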

Compound 4, half-maximal inhibitory concentration: 360 nM
Compound 4: the middle estimate sits 1.1-fold (0.05 log units) above what was measured, within the range that was stated.
By their numbers in this assay, from the lowest: compounds 3, 4 and 2 (each within the scatter of the next, the first and the last beyond it); then compound 1.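

In this assay, phenyl in place of 2,6-dimethylphenyl on the amide-type nitrogen gives a 1.7-fold higher number from compound 3 to compound 4 (0.23 log units; within the scatter), so the two methyl groups are not needed for a number in this range. Hydrogen in place of nitro gives a 1.2-fold lower number from compound 2 to compound 4 (0.08 log units; within the scatter) and leaves the number unresolved from compound 2, whereas hydrogen in place of methoxy gives a 2.6-fold lower number from compound 1 to compound 4 (0.42 log units; beyond the scatter), the only one of these steps beyond the scatter.

From the compounds shown here alone, whether an amine or a carboxylic acid on this aryl ring would shift the number remains open, as does the effect of a longer chain in place of the aryl group. No measurement shown here accounts for the size of these steps.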